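A few compounds are considered here, and "the series" means these few. Any claim that something is new, unique, unknown or untested is made for them only; others in the source may bear on it.

Compound 1 `COc1ccc(OC)c(C2CC(c3ccco3)=NN2C(C)=O)c1` and compound 2 `COc1cc(OC)c(C2CC(c3ccco3)=NN2C(C)=O)cc1OC` share one core; in a functional assay on IMR-32 cells (Homo sapiens) for cytotoxicity, read by sulforhodamine B assay, with a stated time of 48 h (on this read-out higher numbers stand for weaker inhibition and lower numbers for stronger inhibition), compound 1 gives 11800 nM and compound 2 gives 7760 nM. Between them the change is hydrogen in place of methoxy on an aromatic carbon, and the step is a 1.5-fold higher number from compound 2 to compound 1 (0.18 log units; within the scatter). Compound 3 `COc1ccc(C2CC(c3ccc4ccccc4c3)=NN2CC=O)c(OC)c1OC` carries another core, and the difference between the two cores is not broken down here. In this assay compound 3 gives 780 nM, the lowest of the three numbers. Compound 4 `COc1ccc(C2CC(c3ccc4ccccc4c3)=NN2CC=O)cc1OC` is reached from compound 3 through (hydrogen in place of methoxy on an aromatic carbon). Among the measured compounds shown here, this is the same kind of change as the one between compound 2 and compound 1, though the place is not identical: in compound 3 it is ortho to a large group, while in compound 2 it is para to a large group. Because the earlier step was a 1.5-fold higher number from compound 2 to compound 1 (0.18 log units; within the scatter), compound 4 is expected to move only slightly, an estimated 1.5-fold higher number from compound 3 to compound 4 (0.19 log units; within the scatter). Compound 4 is therefore estimated at 1200 nM, likely between 500 nM and 3000 nM.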

Compound 4, half-maximal inhibitory concentration: 1590 nM
Compound 4: middle estimate off by 1.3-fold (0.12 log units), on the low side; low and high end bracket the measured number.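

On the second core, hydrogen in place of methoxy gives a 2.0-fold higher number from compound 3 to compound 4 (0.31 log units; beyond the scatter). Set beside the step on the first core, the two results agree: the same change on two cores in this assay, a 1.5-fold higher number (0.18 log units; within the scatter) from compound 2 to compound 1 and a 2.0-fold higher number (0.31 log units; beyond the scatter) from compound 3 to compound 4, 1.3-fold (0.13 log units) apart, within the scatter of two such steps. Among the compounds shown here, this suggests that the size of the step carried over between these two cores, but it rests on only two pairs with the change at different places on the ring, so it does not show that the step would hold on other cores or at other places.

The compounds shown leave open what a different group at that place would do, such as a hydroxy group, an amine or a carboxylic acid. As far as these compounds go, a longer chain such as ethoxy in place of methoxy also remains open.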